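The source may report more compounds than this note shows. Statements on the series, on what has been measured and on what is new or still open speak of the compounds shown alone.

Of the compounds shown here, three sharing one core have been measured so far. Compound 1 `O=C(Nc1cccc(-n2cc(-c3ccncc3)c(-c3ccc(Cl)c(O)c3)n2)c1)Nc1ccc(Cl)c(Cl)c1` gives 12200 nM in a functional assay on SNB-75 cells (Homo sapiens) for inhibition, read by sulforhodamine B assay, with a stated time of 48 h; on this read-out lower numbers stand for stronger inhibition of growth and higher numbers for weaker inhibition of growth. Compound 2 `COc1cc(-c2nn(-c3cccc(NC(=O)c4ccc(Cl)c(C(F)(F)F)c4)c3)cc2-c2ccncc2)ccc1Cl` gives 29200 nM in this assay, and compound 3 `COc1cc(-c2nn(-c3cccc(NC(=O)Nc4ccc(Cl)c(C(F)(F)F)c4)c3)cc2-c2ccncc2)ccc1Cl` gives 10300 nM in this assay. Going by the values given here, the only single-point step among them, (4-chloro-3-(trifluoromethyl)phenyl)amino in place of 4-chloro-3-(trifluoromethyl)phenyl on a carbonyl carbon, reads a 2.8-fold lower number from compound 2 to compound 3 (0.45 log units; beyond the scatter). Compound 3 thus holds the lowest of the three numbers, but its gap to compound 1 is within the scatter, so the two cannot be ordered.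

Compound 4 `O=C(Nc1cccc(-n2cc(-c3ccncc3)c(-c3ccc(Cl)c(O)c3)n2)c1)Nc1ccc(Cl)c(C(F)(F)F)c1` differs from compound 3 by hydrogen in place of methyl on an oxygen on an aromatic ring. Among the compounds with values here, no measured pair shows this change on its own; compound 1 carries the same hydroxy group but also a different aryl on the other end, so it is only indirect guidance. Since compound 1 with 12200 nM and compound 3 with 10300 nM sit within the scatter of each other, little movement is expected. Compound 4 is therefore estimated at 10000 nM in this assay, between 4000 nM and 25000 nM, a step of a 1.0-fold lower number from compound 3 to compound 4 (0.01 log units; within the scatter) from compound 3 that is expected to stay within the scatter.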

Compound 4, concentration for total growth inhibition: 3200 nM
Estimate against measurement, compound 4: 3.1-fold (0.49 log units) above, and the stated range ends above it.
By their numbers in this assay, from the lowest: compound 4; then compounds 3 and 1 (each within the scatter of the next); then compound 2.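

In this assay, going by these compounds alone, the step at this oxygen is a 3.2-fold lower number from compound 3 to compound 4 (0.51 log units; beyond the scatter) and lies beyond the scatter, so methoxy to hydroxy on the aromatic ring does move the number, which no earlier step could show. With the hydroxy group held fixed, the other end of the molecule also proves to matter: trifluoromethyl in place of chloro on an aromatic carbon gives a 3.8-fold lower number from compound 1 to compound 4 (0.58 log units; beyond the scatter) and places compound 4 lowest of the four. No evidence at hand accounts for either step.

The compounds shown leave open whether hydroxy is special at this position or whether an amino group or a longer ethoxy chain in place of methoxy would read alike. They also leave open whether methoxy to hydroxy would shift compound 2 by a similar amount, or whether this step holds only on the urea-linked compounds.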